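Chloro on the Core: Expected Effect in Compound 4

The source may report more compounds than this note shows. Statements on the series, on what has been measured and on what is new or still open speak of the compounds shown alone.

Compound 1, with structure `Cc1cccc(Cc2nc3cc(O[C@H]4CC[C@@H](C(=O)O)CC4)ccc3n2C)c1`, gives the lowest number of the three measured compounds in an assay on isolated protein for inhibition of Long-chain-fatty-acid--CoA ligase 1 (Homo sapiens), read by mass spectrometry, with a stated time of 90 min, in the presence of a further agent that is not named here (on this read-out lower numbers stand for stronger inhibition and higher numbers for weaker inhibition), at 42 nM. Compound 2, `Cc1cccc(Oc2nc3cc(O[C@H]4CC[C@@H](C(=O)O)CC4)ccc3n2C)c1`, gives 78000 nM in this assay, and compound 3, `Cc1cccc(COc2nc3cc(O[C@H]4CC[C@@H](C(=O)O)CC4)ccc3n2C)c1`, gives 17000 nM. The measured steps all concern the link between the methylphenyl group and the shared core: a 1900-fold higher number from compound 1 to compound 2 (3.27 log units; beyond the scatter), a 400-fold higher number from compound 1 to compound 3 (2.61 log units; beyond the scatter), and a 4.6-fold lower number from compound 2 to compound 3 (0.66 log units; beyond the scatter). None of them touches the core ring itself.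

Compound 4, `Cc1cccc(Cc2nc3cc(O[C@H]4CC[C@@H](C(=O)O)CC4)c(Cl)cc3n2C)c1`, keeps the link of compound 1 and differs only in one place: chloro in place of hydrogen on an aromatic carbon. Among the compounds with values here, no measured pair shows what a substituent at this position does, so the three steps give no direct guide. The change is small in size and leaves the link that distinguishes compound 1 unchanged, so the expectation is a step of a 1.1-fold higher number from compound 1 to compound 4 (0.03 log units; within the scatter), that is, no change beyond the usual scatter. Within the data shown here, compound 4 is therefore expected to give about 45 nM in this assay, within a range from 10 nM to 200 nM, a range kept wide since no measured compound carries a group at this place.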

Compound 4, half-maximal inhibitory concentration: 47 nM
For compound 4 the middle estimate is 1.0-fold (0.02 log units) below the measured one, and the stated range covers the measured number.
By their numbers in this assay, from the lowest: compounds 1 and 4 (each within the scatter of the next); then compound 3; then compound 2.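

In this assay, chloro in place of hydrogen on this aromatic carbon of the shared core gives a 1.1-fold higher number from compound 1 to compound 4 (0.05 log units; within the scatter), so the two numbers lie within the scatter of each other. Within the data shown here, this position, ortho to a large group, therefore accepts a single chlorine atom while the numbers stay in the same range, something the earlier compounds could not show, as they differ only in the link to the methylphenyl group. Those link changes gave steps as large as a 1900-fold higher number from compound 1 to compound 2 (3.27 log units; beyond the scatter), so among the compounds shown, the one change made on the core has far less effect on the number than the link changes. Nothing measured here bears on what lies behind this result.

Going by these compounds, a single chloro cannot show how much this position accepts in general, so it remains open whether methoxy, an amine, a carboxylic acid or a longer chain at the same carbon would also leave the number within the scatter. On these data alone, it is also open whether chloro on the other carbons of this six-membered ring, or with the oxygen link of compound 2, would give a similar result.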